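This account rests on a few compounds, and the source may have more. Where it says the series, first, only, none or still open, it means among the compounds named here.

Working notes on the series. In a functional assay on HL-60 cells (Homo sapiens) for cytotoxicity, read by luminescence and CellTiter-Glo, with a stated time of 3 days (a lower number here means a stronger inhibitor, a higher number a weaker inhibitor), compound 3 `N#Cc1ccc(NC(=O)c2ccccc2O)cc1` gives 4620 nM. Compound 2 `N#Cc1ccc(NC(=O)c2cc(-c3ccncc3)ccc2O)cc1` gives 5410 nM, which is within the scatter of the value for compound 3. Compound 1 `COc1ccc(O)c(C(=O)Nc2ccc(C#N)cc2)c1` gives > 10000 nM, and this is a limit of the assay, not a number.

Compound 4 `N#Cc1ccc(NC(=O)c2cc(Br)ccc2O)cc1` differs from compound 3 as follows: bromo in place of hydrogen on an aromatic carbon. Bromo takes the place of hydrogen on the aromatic carbon para to a hydroxy group.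

Within the data shown here, two measured steps concern that same carbon. One is a 1.2-fold lower number from compound 2 to compound 3 (0.07 log units; within the scatter), and the other is an at least 2.1-fold lower number from compound 1 to compound 3 (0.33 log units; beyond the scatter). The two groups involved therefore gave different outcomes: pyridin-4-yl left no step beyond the scatter, while methoxy left at least a modest one. From the compounds shown here alone, neither is bromo, so the direction stays open, and no step beyond the scatter is expected in this assay. The expected step is a 1.5-fold lower number from compound 3 to compound 4 (0.19 log units; within the scatter). For compound 4 the estimated value is 3000 nM, with an expected range of 900 nM to 9000 nM.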

Compound 4, half-maximal inhibitory concentration: 620 nM
Compound 4: the middle estimate sits 4.8-fold (0.68 log units) above what was measured; the measured number lies below the stated range.
By their numbers in this assay, from the lowest: compound 4; then compounds 3 and 2 (each within the scatter of the next). At a limit, above all of these: compound 1.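

In this assay, among these compounds, the aromatic carbon para to a hydroxy group now proves able to give a number lower than hydrogen does, with a 7.5-fold lower number from compound 3 to compound 4 (0.87 log units; beyond the scatter), whereas the earlier compounds showed only no step beyond the scatter or a higher number at this carbon. Bromo also separates from the other two groups on that carbon, with an 8.7-fold lower number from compound 2 to compound 4 (0.94 log units; beyond the scatter) and an at least 16-fold lower number from compound 1 to compound 4 (1.20 log units; beyond the scatter). The last of these steps is only a floor, since the entry for compound 1 is a limit of the assay and not a number: the limit of > 10000 nM in this assay, at which 1 of the 4 values shown sits.

The compounds shown leave open whether chloro, iodo or methyl on this carbon would give a number close to that of compound 4 or to that of compound 3. They also leave open whether the step from hydrogen to bromo persists when an amine takes the place of the nitrile.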